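The compounds below may be only part of what the source reports. "The series", "measured", "known", "first", "only" and "open" are said of these compounds alone.

Of the compounds shown here, three have been measured in a functional assay on PC-3 cells (Homo sapiens) for cytotoxicity, read by sulforhodamine B assay, with a stated time of 48 h; on this read-out lower numbers stand for stronger inhibition and higher numbers for weaker inhibition. Compound 1 `CC(=O)N1N=C(c2ccco2)CC1c1ccccc1[N+](=O)[O-]` gives 19000 nM, and compound 2 `CC(=O)N1N=C(c2ccco2)CC1c1cccc(O)c1` gives 16500 nM, two numbers that lie within the scatter of each other. Compound 3 `O=CCN1N=C(c2ccc3ccccc3c2)CC1c1ccccc1[N+](=O)[O-]` gives 3010 nM, the lowest of the three and well beyond the scatter from both others. The step to compound 4 `O=CCN1N=C(c2ccc3ccccc3c2)CC1c1cccc(Br)c1` is 3-bromophenyl in place of 2-nitrophenyl on a saturated ring carbon. Compounds 1 and 2 show that swapping the group on that saturated ring carbon changed little, so only a small shift is expected for a 1.0-fold lower number from compound 3 to compound 4 (0.00 log units; within the scatter), in no firm direction and likely within the scatter. Compound 4 is therefore estimated at 3000 nM, with a range from 1000 nM to 9000 nM.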

Compound 4, half-maximal inhibitory concentration: 10900 nM
The estimate for compound 4 lay 3.6-fold (0.56 log units) below the measured number, and the stated range ends below it.
By their numbers in this assay, from the lowest: compound 3; then compounds 4, 2 and 1 (each within the scatter of the next).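

Replacing 2-nitrophenyl with 3-bromophenyl on this saturated ring carbon gives a 3.6-fold higher number from compound 3 to compound 4 (0.56 log units; beyond the scatter). The group at this position can therefore move the number beyond the scatter, which compounds 1 and 2, with values within the scatter of each other, did not show. No measured evidence here explains this shift. The step swaps the substituent and its place on the phenyl ring together, and these compounds cannot tell the two changes apart. Going by these compounds, how a plain phenyl or an aminophenyl group would fare at this carbon stays open.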